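This account rests on a few compounds, and the source may have more. Where it says the series, first, only, none or still open, it means among the compounds named here.

Working notes on the series in a functional assay on L02 cells (Homo sapiens) for inhibition, read by MTT assay, with a stated time of 48 h; on this read-out higher numbers stand for weaker inhibition and lower numbers for stronger inhibition. Compound 1 (`COc1ccc2c(=O)c(/C=C/C(=O)Nc3cccc(C)c3)coc2c1`) reads > 200000 nM as a limit of the assay, not a number. Compound 2 (`COc1ccc2c(=O)c(/C=C/C(=O)Nc3cccc(Cl)c3)coc2c1`) reads > 200000 nM and is likewise only a limit. Compound 3 (`COc1ccc(CNC(=O)/C=C/c2coc3cc(O)ccc3c2=O)cc1`) reads > 200000 nM and is also only a limit. Compound 2 therefore has no exact position, and nothing in the series ranks above or below it.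

The next compound is compound 4 (`COc1ccc2c(=O)c(/C=C/C(=O)NCc3ccccc3)coc2c1`), which has benzyl in place of 3-chlorophenyl on an amide-type nitrogen.

For the measured compounds named here, the one measured step, a step that the two limits leave unreadable from compound 1 to compound 2, gives no usable size. Compound 3 also has a benzyl group, here substituted, on an amide-type nitrogen, but it differs from compound 4 elsewhere too, so it offers only loose support.

Because (the limit of > 200000 nM in this assay, at which 3 of the 3 values shown sit), no step beyond the scatter and no direction is expected in this assay for this change. The expected a number no higher from compound 2 to compound 4 (the limit leaves the size open) is accordingly no real change, though its true size cannot be measured against a limit. For compound 4 the estimated value is 200000 nM, with an expected range of 100000 nM to 400000 nM, and another report as a limit is the likeliest outcome.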

Compound 4, half-maximal inhibitory concentration: > 200000 nM
Compound 4: no number, only a limit (the forecaster's own chance of this, stated with the estimate: 85%); the middle value sits exactly at the limit.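

In this assay compound 4 gives > 200000 nM, a limit of the assay and not a number. The steps to compound 4 from compound 1 and from compound 2 therefore cannot be read: the limit of > 200000 nM in this assay, at which 4 of the 4 values shown sit.

The compounds shown leave open how benzyl and 3-chlorophenyl on the amide-type nitrogen compare, since none of them gives an exact value.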